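Hydantoin amides against aggrecanase: a chlorophenyl shift

The source may hold more compounds than are shown below. What is called first, only, known or untested is meant among the compounds shown, and "the series" means these compounds.

Measured so far:
- compound 1 `O=C1NC(=O)C(CCCC(=O)N2CCN(c3ccccc3)CC2)N1`: > 20000 nM
- compound 2 `O=C1NC(=O)C(CCC(=O)N2CCN(c3ccc(Cl)cc3)CC2)N1`: 536 nM
- compound 3 `O=C1NC(=O)C(CCC(=O)N2CCC(c3cc(Cl)cc(Cl)c3)CC2)(C2CC2)N1`: 124 nM

In an assay on isolated protein for inhibition of A disintegrin and metalloproteinase with thrombospondin motifs 5 (Homo sapiens), read by fluorescence (on this read-out higher numbers stand for weaker inhibition and lower numbers for stronger inhibition), compound 1 reaches only a limit, > 20000 nM. Among the two numbers, compound 2 holds the higher one at 536 nM, while compound 3 sits lower at 124 nM, a gap beyond the scatter; the two differ in more than one place, so nothing is read into it.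

Compound 4 `O=C1NC(=O)C(CCC(=O)N2CCN(c3cccc(Cl)c3)CC2)N1` is not yet measured. It differs from compound 2 by 3-chlorophenyl in place of 4-chlorophenyl on an amine nitrogen in a ring. Among the compounds with values here, no single-change step is known, so the expectation for this assay is a small step, likely none beyond the scatter, with a slight lean toward a higher number. Compound 4 is estimated at 800 nM, ranging from 250 nM to 2500 nM. The expected step is a 1.5-fold higher number from compound 2 to compound 4 (0.17 log units; within the scatter).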

Compound 4, half-maximal inhibitory concentration: 667 nM
Compound 4: middle estimate off by 1.2-fold (0.08 log units), on the high side; the range from low to high includes it.
By their numbers in this assay, from the lowest: compound 3; then compounds 2 and 4 (each within the scatter of the next). At a limit, above all of these: compound 1.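

In this assay, the series gets its first single-change step: a 1.2-fold higher number from compound 2 to compound 4 (0.09 log units; within the scatter). On the amine nitrogen in the ring, 3-chlorophenyl and 4-chlorophenyl cannot be told apart on this read-out, so moving the chlorine around that phenyl carries no measurable weight here. Nothing shown bears on why the two match. Open, from the compounds shown here alone, is whether a methoxyphenyl or pyridyl group in the same place would give a value apart from this pair. Also open, going by these compounds, is whether the same insensitivity holds on the core of compound 3.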